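Extending the Aryl Arm: From Methylphenyl to Phenylethenyl

The compounds below may be only part of what the source reports. "The series", "measured", "known", "first", "only" and "open" are said of these compounds alone.

Three sugar-bearing compounds have been measured: compound 1 `COc1ccc2c(c1)c(/C=C1/C(=O)Nc3ccc(F)cc31)cn2Cc1cn([C@@H]2O[C@H](COC(C)=O)[C@@H](OC(C)=O)[C@H](OC(C)=O)[C@H]2OC(C)=O)nn1`, compound 2 `CC(=O)OC[C@H]1O[C@@H](n2cc(CN3C(=O)/C(=C/c4ccc(C)cc4)c4ccccc43)nn2)[C@H](OC(C)=O)[C@@H](OC(C)=O)[C@@H]1OC(C)=O` and compound 3 `CC(=O)OC[C@H]1O[C@@H](n2cc(CN3C(=O)/C(=C\c4ccc(C)cc4)c4ccccc43)nn2)[C@H](OC(C)=O)[C@@H](OC(C)=O)[C@@H]1OC(C)=O`. In a functional assay on DU-145 cells (Homo sapiens) for cytotoxicity, read by sulforhodamine B assay, with a stated time of 48 h (on this read-out lower numbers stand for stronger inhibition and higher numbers for weaker inhibition), compound 1 gives only a limit, > 200000 nM. Compound 2 gives 9300 nM, and compound 3 gives 9400 nM; the change a 1.0-fold higher number from compound 2 to compound 3 (0.00 log units; within the scatter) stays within the scatter, in line with the fact that compounds 2 and 3 differ only in the configuration as drawn. Compound 3 thus holds one of the two numbered values, and it and compound 2 cannot be told apart. Compound 4 `CC(=O)OC[C@H]1O[C@@H](n2cc(CN3C(=O)/C(=C\C=C\c4ccccc4)c4ccccc43)nn2)[C@H](OC(C)=O)[C@@H](OC(C)=O)[C@@H]1OC(C)=O` differs from compound 3 by 2-phenylethenyl in place of 4-methylphenyl on a double-bonded chain carbon bound to a double-bonded ring carbon. Among the compounds with values here, no measured step touches this position, and the only measured step was flat, so no shift beyond the scatter is expected; the expected shift is a 1.0-fold lower number from compound 3 to compound 4 (0.02 log units; within the scatter). Compound 4 is expected to give 9000 nM, between 3000 nM and 30000 nM.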

Compound 4, half-maximal inhibitory concentration: 19500 nM
Beside the measured number, compound 4's estimate is 2.2-fold (0.34 log units) below it; the measured number falls inside the stated range.
By their numbers in this assay, from the lowest: compounds 2 and 3 (each within the scatter of the next); then compound 4. At a limit, above all of these: compound 1.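

Within the data shown here, this position is the first place where a change moves the number beyond the scatter: in this assay, 2-phenylethenyl in place of 4-methylphenyl gives a 2.1-fold higher number from compound 3 to compound 4 (0.32 log units; beyond the scatter), a modest loss of inhibition. The group on this double-bonded chain carbon therefore registers in the read-out, whereas the drawn configuration of the double bond in compounds 2 and 3 did not. Nothing measured here accounts for this step.

Going by these compounds, it remains open whether the loss follows the added double bond or the missing methyl. On these data alone, how an amine at this position would read also remains open.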